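Swapping a Methylphenyl for a Thiophenyl on One Core

This account rests on a few compounds, and the source may have more. Where it says the series, first, only, none or still open, it means among the compounds named here.

Of the compounds shown here, three sharing one core have been measured in an assay on Sf9 cells for inhibition of protein deacetylase HDAC6 (Homo sapiens), read by fluorescence, with a stated time of 40 min, tested at 100 nM; a lower number here means less inhibition, a higher number more inhibition at the concentration tested (going by the name of the read-out). Compound 1 `O=C(NO)c1ccc(NCc2nc(-c3ccccc3)nn2-c2cccc(Cl)c2)cc1` gives 62.3%. Within the data shown here, compound 3 `O=C(NO)c1ccc(NCc2nc(-c3ccccc3)nn2-c2ccc(Cl)cc2)cc1` gives 55.4%, and the only step recorded between measured compounds, a number 6.9 percentage points lower from compound 1 to compound 3 (within the scatter), lies within the scatter. Compound 2 `Cc1ccccc1-c1nc(CNc2ccc(C(=O)NO)cc2)n(-c2ccccc2)n1` gives 53.2%, the lowest of the three numbers, yet its gaps to compound 3 and to compound 1 both fall within the scatter, so no order among the three can be read from these results.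

Compound 4 `O=C(NO)c1ccc(NCc2nc(-c3ccsc3)nn2-c2ccccc2)cc1` has not yet been measured. The change from compound 2 is thiophen-3-yl in place of 2-methylphenyl on an aromatic carbon. Among the measured compounds shown here, the one measured step concerns a chlorophenyl on an aromatic nitrogen, a different place from this one, so nothing measured bears directly on the change; the numbers only show that the three analogues sit close together. For the measured compounds named here, with no step to build on, the step in this assay is expected to be a number 1.8 percentage points higher from compound 2 to compound 4 (within the scatter), nothing beyond the scatter. Compound 4 is therefore estimated at 55%, with a range from 35% to 75%.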

Compound 4, a percentage reported as inhibition, at one concentration (the size of the read-out at that concentration, not a potency): 53.4%
For compound 4 the middle estimate is 1.6 percentage points above the measured one; the range from low to high includes it.
By their numbers in this assay, from the lowest: compounds 2, 4, 3 and 1 (each within the scatter of the next).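

The first step read at this position, on an aromatic carbon of the five-membered aromatic ring with 3 nitrogen, is a number 0.2 percentage points higher from compound 2 to compound 4 (within the scatter) in this assay. At the concentration tested, this read-out therefore cannot separate 2-methylphenyl, with 7 heavy atoms, all carbon, from thiophen-3-yl, with 5 heavy atoms including a sulfur, so this position accepts either group with no visible change. No measured information is available to explain why the two groups read alike.

The compounds shown compare only these two aromatic groups here, leaving open how an amine, a carboxylic acid or a longer chain would read at the same carbon. They also leave open whether thiophen-3-yl would read the same alongside the chlorophenyl groups of compound 1 and compound 3.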